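Ring Closure at the Terminal Amine of the Side Chain

A few compounds are considered here, and "the series" means these few. Any claim that something is new, unique, unknown or untested is made for them only; others in the source may bear on it.

Compound 3 `CCN(CC)CCCOc1cc2ncnc(Nc3nc4ccc(C(=O)Nc5c(C)cccc5Cl)cc4s3)c2cc1OC` stands highest of the two numbers seen in a functional assay on NCI-H661 cells (Homo sapiens) for cytotoxicity, read by WST assay, with a stated time of 72 h (a lower number here means a stronger inhibitor, a higher number a weaker inhibitor), where compound 3 gives 11200 nM. Compound 1 `COc1cc2c(Nc3nc4ccc(C(=O)Nc5c(C)cccc5Cl)cc4s3)ncnc2cc1OCCCN1CCCCC1C` gives 5300 nM in this assay, and the change a 2.1-fold higher number from compound 1 to compound 3 (0.32 log units; beyond the scatter). Compound 2 `COc1cc2c(Nc3nc4ccc(C(=O)Nc5c(C)cccc5C)cc4s3)ncnc2cc1OCCCN1CCCC1` gives > 100000 nM in this assay, which is a limit of this assay (the limit of > 100000 nM in this assay, at which 1 of the 3 values shown sits). Compound 4 `COc1cc2c(Nc3nc4ccc(C(=O)Nc5c(C)cccc5Cl)cc4s3)ncnc2cc1OCCCN1CCCC1` differs from compound 3 by pyrrolidin-1-yl in place of diethylamino on a saturated chain carbon, three bonds along the chain from an oxygen on an aromatic ring. Among the measured compounds shown here, compound 2 carries the same entering group but differs from compound 4 in a second place as well, so it sets no step. For the measured compounds named here, the one measured change at this amine, a 2.1-fold higher number from compound 1 to compound 3 (0.32 log units; beyond the scatter), was modest, so a modest step back down, or none beyond the scatter, is expected for compound 4. Compound 4 is therefore estimated at 6500 nM in this assay, within 2500 nM to 16000 nM, a step of a 1.7-fold lower number from compound 3 to compound 4 (0.24 log units; within the scatter).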

Compound 4, half-maximal inhibitory concentration: 45500 nM
Beside the measured number, compound 4's estimate is 7.0-fold (0.85 log units) below it; measured number above the stated range.
By their numbers in this assay, from the lowest: compound 1; then compound 3; then compound 4. At a limit, above all of these: compound 2.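

In this assay, the ring at the terminal amine does not bring the number back toward compound 1: the step is a 4.1-fold higher number from compound 3 to compound 4 (0.61 log units; beyond the scatter), and the full distance is an 8.6-fold higher number from compound 1 to compound 4 (0.93 log units; beyond the scatter), so the two ring-bearing amines lie on either side of diethylamino and a ring alone does not set the order. On the aromatic carbon, chloro in place of methyl gives an at least 2.1-fold lower number from compound 2 to compound 4 (0.34 log units; beyond the scatter), a step read from a limit and not from a number. Compound 2 stands at that limit: the limit of > 100000 nM in this assay, at which 1 of the 4 values shown sits.

The compounds shown leave open where an unsubstituted piperidin-1-yl or a morpholine would fall among these amines. They also leave open whether a shorter chain would change the distance between them.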